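The compounds below may be only part of what the source reports. "The series", "measured", "known", "first", "only" and "open" are said of these compounds alone.

Measured in a functional assay on MCF7 cells (Homo sapiens) for inhibition, read by MTT assay, with a stated time of 72 h; on this read-out higher numbers stand for weaker inhibition and lower numbers for stronger inhibition:
- compound 1 `Nc1nc2cc(-c3nn(CCCC(=O)NO)c4ncnc(N)c34)ccc2o1`: > 50000 nM (a limit)
- compound 2 `Nc1nc2cc(-c3nn(CCC(=O)NO)c4ncnc(N)c34)ccc2o1`: > 100000 nM (a limit)

The value of compound 2, > 100000 nM, is a limit and not a number. For the measured compounds named here, the one other value is a limit too.

Next is compound 3 `Nc1nc2cc(-c3nn(CCCCC(=O)NO)c4ncnc(N)c34)ccc2o1`, which carries 2-(hydroxycarbamoyl)ethyl in place of hydroxycarbamoyl on a saturated chain carbon, two bonds along the chain from an aromatic nitrogen.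

Going by the values given here, only one measured step bears on this change on the same chain: a step that the two limits leave unreadable from compound 1 to compound 2. It has no readable size, so it fixes neither the size nor the direction of the next step.

Compound 1 also offers no number, only the limit > 50000 nM, so strong inhibition is not expected in this assay. The estimated step is small, an at least 1.6-fold lower number from compound 2 to compound 3 (0.22 log units; that floor lies within the scatter), and may well end in another limit.

For compound 3 the expected value is 60000 nM, with an estimated range of 15000 nM to 100000 nM.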

Compound 3, half-maximal inhibitory concentration: 14000 nM
For compound 3 the middle estimate is 4.3-fold (0.63 log units) above the measured one; the whole stated range lies above it.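

In this assay, for the compounds shown here, compound 3 gives the first number of the series rather than a limit, 14000 nM, so inhibition at this position becomes measurable with the longest of the three chains. Putting 2-(hydroxycarbamoyl)ethyl in place of hydroxycarbamoyl gives an at least 7.1-fold lower number from compound 2 to compound 3 (0.85 log units; beyond the scatter), and putting (hydroxycarbamoyl)methyl in place of hydroxycarbamoyl, three bonds along the chain from an aromatic nitrogen, gives an at least 3.5-fold lower number from compound 1 to compound 3 (0.55 log units; beyond the scatter). Both sizes are floors set by limits, and the step between the two shorter chains cannot be read, so the direction is fixed only for compound 3 against each of the others.

On these data alone, whether a longer chain than that of compound 3 would lower the number further remains open. So does the effect of a carboxylic acid in place of the hydroxycarbamoyl end on the same chain.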